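Swapping the aryl group on compound 3's core

The compounds below may be only part of what the source reports. "The series", "measured", "known", "first", "only" and "open" are said of these compounds alone.

Measured so far:
compound 1 `Cn1ncc2cc(-c3cnc4[nH]ncc4c3N3CCC4(CCNC4=O)CC3)ccc21` — 214 nM
compound 2 `Cn1ncc2cc(-c3cnc4[nH]cnc4c3N3CCC4(CCNC4=O)CC3)ccc21` — 5 nM
compound 3 `Cn1cnc2ccc(-c3cnc4[nH]ccc4c3N3CCC4(CCNC4=O)CC3)cc21` — 11 nM

Of the compounds shown here, three have been tested in an assay on cells for binding affinity to Cyclin-C/Cyclin-dependent kinase 19 (Homo sapiens), read by LanthaScreen; on this read-out higher numbers stand for weaker inhibition and lower numbers for stronger inhibition. Compound 1 `Cn1ncc2cc(-c3cnc4[nH]ncc4c3N3CCC4(CCNC4=O)CC3)ccc21` gives 214 nM, compound 2 `Cn1ncc2cc(-c3cnc4[nH]cnc4c3N3CCC4(CCNC4=O)CC3)ccc21` gives 5 nM, and compound 3 `Cn1cnc2ccc(-c3cnc4[nH]ccc4c3N3CCC4(CCNC4=O)CC3)cc21` gives 11 nM. Compound 3 thus stands second highest of the three numbers: compound 2 lies nearest, with a number lower by more than the scatter, while compound 1 lies furthest, with a far higher number. For the measured compounds named here, these three differ in their cores, and no single-change step links any pair of them, so the numbers speak only for themselves.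

Compound 4 `O=C1NCCC12CCN(c1c(-c3ccc4ncnn4c3)cnc3[nH]ccc13)CC2` keeps the core of compound 3 and differs only in the aryl group: a group of 9 heavy atoms (6 carbon, 3 nitrogen; one five-membered aromatic ring with 3 hetero atoms, one six-membered aromatic ring with 1 hetero atom) in place of a group of 10 heavy atoms (8 carbon, 2 nitrogen; one five-membered aromatic ring with 2 hetero atoms, one six-membered aromatic ring of carbon only), on an aromatic carbon. Going by the values given here, no measured pair covers a change of this kind. The group that enters is close in size to the one that leaves, so compound 4 is expected to stay near compound 3, with a step of a 1.4-fold higher number from compound 3 to compound 4 (0.13 log units; within the scatter) that need not go beyond the scatter. Compound 4 is therefore estimated at 15 nM, within 5 nM to 50 nM.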

Compound 4, half-maximal inhibitory concentration: 1020 nM
Compound 4: middle estimate off by 68-fold (1.83 log units), on the low side; the measured number lies above the stated range.
By their numbers in this assay, from the lowest: compound 2; then compound 3; then compound 1; then compound 4.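

In this assay, for the compounds shown here, the aryl position on the core of compound 3 proves highly sensitive to the identity of the group it carries, a point the earlier compounds could not show because no single-change step linked them. Replacing 1-methyl-1H-benzimidazol-6-yl with a group of nearly the same size, with 3 hydrogen-bond acceptors against 2, gives a 93-fold higher number from compound 3 to compound 4 (1.97 log units; beyond the scatter), so closeness in size did not keep the number close here. Nothing measured here explains this loss.

With only these two groups compared at this position, the feature of the entering group that goes with the loss remains unresolved. As far as these compounds go, it also remains open whether a plain phenyl or a 1-methylpyrazol-4-yl group on the same core would stay near compound 3 or move towards compound 4.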